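Hydroxy on the phenyl of compound 3: outlook for compound 4

The source may hold more compounds than are shown below. What is called first, only, known or untested is meant among the compounds shown, and "the series" means these compounds.

Measured compounds in a functional assay on the whole organism (strain albino) for inhibition, with Rattus norvegicus as the target, read by paw edema, with stated times of 1 h and 2 h, at a dose of 100 mg/kg by the oral route; a higher number here means more inhibition at the dose given (going by the name of the read-out), a lower number less inhibition:
- compound 1, `O=C(CSc1nc(-c2ccc(Cl)cc2)c(C(=O)O)c(=O)[nH]1)Nn1c(COc2ccc(Cl)cc2Cl)nc2ccccc2c1=O`, gives 61.4%
- compound 2, `N#Cc1c(-c2ccc(Cl)cc2)nc(SCC(=O)Nn2c(COc3ccc(Cl)cc3Cl)nc3ccccc3c2=O)n(Cc2ccccc2)c1=O`, gives 77.2%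
- compound 3, `N#Cc1c(Cl)nc(SCC(=O)Nn2c(COc3ccc(Cl)cc3Cl)nc3ccccc3c2=O)nc1-c1ccccc1`, gives 66.7%

Compound 3 sits second of the three numbers in this assay. Its nearest neighbour is compound 1, whose number is lower by a gap that lies within the scatter, so the two cannot be ordered. Compound 2 stands higher than compound 3 by a gap beyond the scatter. For the measured compounds named here, no pair among the three differs in one place only, so no single step within the measured set can be read off.

Compound 4, `N#Cc1c(Cl)nc(SCC(=O)Nn2c(COc3ccc(Cl)cc3Cl)nc3ccccc3c2=O)nc1-c1ccc(O)cc1`, is not yet measured. It differs from compound 3 in one place: hydroxy in place of hydrogen on an aromatic carbon.

Going by the values given here, nothing in the measured set carries a change of this kind, so no comparable step is available. The expected step from compound 3 to compound 4 in this assay is therefore none beyond the scatter, in either direction, and it is estimated as a number 0.7 percentage points lower from compound 3 to compound 4 (within the scatter).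

For compound 4 the expected value in this assay is 66%, with a range from 52% to 78%.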

Compound 4, a percentage reported as inhibition, in the whole organism at one dose (the size of the read-out at that dose, not a potency): 73.7%
Compound 4: the middle estimate sits 7.7 percentage points below what was measured; low and high end bracket the measured number.
By their numbers in this assay, from the lowest: compounds 1, 3, 4 and 2 (each within the scatter of the next, the first and the last beyond it).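

Phenyl to 4-hydroxyphenyl is the first change in this series that can be read at a single place, and in this assay it comes to a number 7 percentage points higher from compound 3 to compound 4 (within the scatter) on the aromatic ring, at the carbon para to a large group. This place therefore accepts a hydroxy, which brings a hydrogen-bond donor and acceptor, with no loss of inhibition beyond the usual scatter, though no gain can be claimed for it either. Nothing measured here bears on why the step has this size.

As far as these compounds go, whether a methoxy, an amine or a carboxylic acid at the same carbon would keep the number in this range stays open, as does the effect of a hydroxy at other carbons of this phenyl ring. From the compounds shown here alone, the read-out is taken at one dose, so any difference in potency between the two compounds also stays open, and the hydroxy is seen on this one background only, with the cores of compound 1 and compound 2 differing in more than one place.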